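This account rests on a few compounds, and the source may have more. Where it says the series, first, only, none or still open, it means among the compounds named here.

Going by the values given here, compound 2 `NS(=O)(=O)Oc1ccc2c(c1)CN(C(=O)c1cccc(N3CCCCC3)c1)CC2` gives 11.9% in an assay on HEK293 cells for inhibition of Steryl-sulfatase (Homo sapiens), tested at 1 uM (on this read-out lower numbers stand for a weaker effect and higher numbers for a stronger effect at the one concentration tested), the lowest of the three numbers known here. Compound 1 `NS(=O)(=O)Oc1ccc2c(c1)CN(C(=O)c1cccc(N3CCC(Cc4ccccc4)CC3)c1)CC2`, which carries a benzyl on the saturated ring, gives 41.9%, and compound 3 `NS(=O)(=O)Oc1ccc2c(c1)CN(C(=O)c1ccc(N(CCCO)Cc3ccccc3)cc1)CC2`, with an open-chain amine bearing a benzyl, gives 64.3%. Compound 4 `CCN(Cc1ccncc1)c1cccc(C(=O)N2CCc3ccc(OS(N)(=O)=O)cc3C2)c1` has not yet been measured. Among the compounds with values here, the one step that bears on its change is a number 30 percentage points lower from compound 1 to compound 2 (beyond the scatter), which shows that taking an aromatic arm away lowered the read-out by a modest amount. Compound 4 differs from compound 2 as follows: ethyl((pyridin-4-yl)methyl)amino in place of piperidin-1-yl on an aromatic carbon. Since an aromatic arm returns, an upward step of similar size is expected, with an estimated a number 26.1 percentage points higher from compound 2 to compound 4 (beyond the scatter), so compound 4 is expected to give 38%, within 15% to 60%.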

Compound 4, a percentage reported as inhibition, at one concentration (the size of the read-out at that concentration, not a potency): 52.8%
Compound 4: middle estimate off by 14.8 percentage points, on the low side, and the stated range covers the measured number.
By their numbers in this assay, from the lowest: compound 2; then compound 1; then compound 4; then compound 3.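

In this assay, ethyl((pyridin-4-yl)methyl)amino in place of piperidin-1-yl on an aromatic carbon gives a number 40.9 percentage points higher from compound 2 to compound 4 (beyond the scatter), a large step. This place, meta to a large group, therefore accepts an open-chain amine carrying a six-membered aromatic ring with a hetero atom, which the step on the saturated ring could not show. Nothing available here explains the rise. Going by these compounds, it remains open whether the ring nitrogen contributes to this gain, as a plain benzyl in place of the (pyridin-4-yl)methyl arm would test. On these data alone, the share of the ethyl is also open, and a propyl or a longer chain there would address it.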